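The source may hold more compounds than are shown below. What is called first, only, known or untested is meant among the compounds shown, and "the series" means these compounds.

Measured compounds in an ADME assay on MT4 cells (Homo sapiens) for cytotoxicity; on this read-out higher numbers stand for lower toxicity in this test and lower numbers for higher toxicity in this test:

Compound 1 `COc1ccc(-c2nnsc2SCC(=O)Nc2ccccc2Br)cc1`. For compound 1 the value is a limit of the test, > 286000 nM.
Compound 2 `O=C(CSc1snnc1-c1ccc(F)cc1F)Nc1ccccc1[N+](=O)[O-]`. In this assay compound 2 gives 165000 nM.
Compound 3 `O=C(CSc1snnc1-c1ccc(F)cc1F)Nc1ccccc1Cl`. In this assay compound 3 gives 178000 nM.

Within the data shown here, compound 3 and compound 2 are the only two compounds with a number rather than a limit, and the two lie within the scatter of each other, as the step of a 1.1-fold higher number from compound 2 to compound 3 (0.03 log units; within the scatter) shows. Among the measured compounds shown here, that step is the one measured change on the same ring position as the change now in question.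

Compound 4 `O=C(CSc1snnc1-c1ccc(F)cc1F)Nc1ccccc1Br` differs from compound 3 in a single place: bromo in place of chloro on an aromatic carbon. For the measured compounds named here, the one measured step that bears on this, a 1.1-fold higher number from compound 2 to compound 3 (0.03 log units; within the scatter), swapped a nitro for a chloro at that position and produced no change beyond the scatter. Exchanging one halogen for another, chloro for bromo, is a smaller change than that, so no movement beyond the scatter is expected in this assay either; the estimated step of a 1.1-fold higher number from compound 3 to compound 4 (0.03 log units; within the scatter) is small. For compound 4 the estimate in this assay is 190000 nM, with a range from 95000 nM to 380000 nM.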

Compound 4, half-maximal cytotoxic concentration: 144000 nM
Beside the measured number, compound 4's estimate is 1.3-fold (0.12 log units) above it, and the stated range covers the measured number.
By their numbers in this assay, from the lowest: compounds 4, 2 and 3 (each within the scatter of the next). At a limit, above all of these: compound 1.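

In this assay, bromo in place of chloro on this aromatic carbon gives a 1.2-fold lower number from compound 3 to compound 4 (0.09 log units; within the scatter), and bromo in place of nitro gives a 1.1-fold lower number from compound 2 to compound 4 (0.06 log units; within the scatter), so nitro, chloro and bromo all give numbers within the scatter of one another. Among these compounds, the earlier compounds offered only one swap at this place, between nitro and chloro, whereas the picture now spans three groups and includes an exchange of one halogen for another. The other single change, 2,4-difluorophenyl in place of 4-methoxyphenyl, gives an at least 1.9-fold lower number from compound 1 to compound 4 (0.29 log units; that floor lies within the scatter), but the floor of that step lies within the scatter and compound 1 sits at a limit of the test, so no real change can be claimed for it: the limit of > 286000 nM in this assay, at which 1 of the 4 values shown sits.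

On these data alone, whether the read-out stays as flat with an amine or a carboxylic acid on this aromatic carbon remains open, since the three groups compared here are only a nitro and two halogens. Also open, as far as these compounds go, is how far compound 1 truly lies from compound 4, and whether a hydroxyl in place of the methoxy on that other ring would give a number rather than a limit.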